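Removing Both Hydroxyls From the Aromatic Tail of Compound 2

A few compounds are considered here, and "the series" means these few. Any claim that something is new, unique, unknown or untested is made for them only; others in the source may bear on it.

Three measured compounds share one core and were tested in a functional assay on Caco-2 cells (Homo sapiens) for antiproliferative activity, read by MTT assay, with a stated time of 72 h; a lower number here means a stronger inhibitor, a higher number a weaker inhibitor. Compound 1 `CC(=O)Oc1ccc(/C=C/C(=O)OCCSc2nc(-c3ccc(S(C)(=O)=O)cc3)n(-c3ccc(C(F)(F)F)cc3)n2)cc1OC(C)=O` gives 11300 nM. Compound 2 `CS(=O)(=O)c1ccc(-c2nc(SCCCOC(=O)/C=C/c3ccc(O)c(O)c3)nn2-c2ccc(Br)cc2)cc1` gives 12400 nM, the highest of the three numbers, though its gaps to compound 1 and to compound 3 `CS(=O)(=O)c1ccc(-c2nc(SCCCOC(=O)/C=C/c3ccc(O)c(O)c3)nn2-c2ccc(F)cc2)cc1`, which gives 11200 nM, are both within the scatter. For the measured compounds named here, the only single-point step, a 1.1-fold lower number from compound 2 to compound 3 (0.04 log units; within the scatter), concerns a different position. Compound 4 `CS(=O)(=O)c1ccc(-c2nc(SCCCOC(=O)/C=C/c3ccccc3)nn2-c2ccc(Br)cc2)cc1` differs from compound 2 by phenyl in place of 3,4-dihydroxyphenyl on a double-bonded chain carbon bound to a double-bonded chain carbon. Going by the values given here, no measured step covers this change, so the expectation rests on the narrow spread of the three numbers. Compound 4 is estimated at 15000 nM, with a range from 5000 nM to 45000 nM. The expected step is a 1.2-fold higher number from compound 2 to compound 4 (0.08 log units; within the scatter), none beyond the scatter.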

Compound 4, half-maximal inhibitory concentration: 24600 nM
Compound 4: the middle estimate sits 1.6-fold (0.21 log units) below what was measured, and the stated range covers the measured number.
By their numbers in this assay, from the lowest: compounds 3, 1, 2 and 4 (each within the scatter of the next, the first and the last beyond it).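

In this assay, for the compounds shown here, this is the first look at the aromatic tail: phenyl in place of 3,4-dihydroxyphenyl gives a 2.0-fold higher number from compound 2 to compound 4 (0.30 log units; within the scatter). Taking away both hydroxyls therefore leaves compound 4 within the scatter of compound 2, so these two compounds give no firm sign that the hydroxyls matter for this read-out. Nothing available here explains this result. Still open, on these data alone, is whether a single hydroxyl would behave like the pair, and whether a methoxy group, an amine or a carboxylic acid on that phenyl would shift the number beyond the scatter.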